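This account rests on a few compounds, and the source may have more. Where it says the series, first, only, none or still open, it means among the compounds named here.

Measured compounds: compound 1 `COc1ccc(N2CCN(C(=S)SCc3ccc(C(=O)Nc4ccccc4N)cc3)CC2)cc1` with 22.9%; compound 2 `CC1CCCCN1C(=S)SCc1ccc(C(=O)Nc2ccccc2N)cc1` with 86.9%; compound 3 `CC1CCN(C(=S)SCc2ccc(C(=O)Nc3ccccc3N)cc2)CC1` with 81.9%.

In a functional assay on MGC-803 cells (Homo sapiens) for antiproliferative activity, read by CCK-8 assay, with a stated time of 72 h, tested at 8 uM (on this read-out lower numbers stand for a weaker effect and higher numbers for a stronger effect at the one concentration tested), compound 1 stands lowest of the three, far beneath both compound 2 and compound 3, whose own difference, a number 5 percentage points lower from compound 2 to compound 3 (within the scatter), is within the scatter. Compound 4 `Nc1ccccc1NC(=O)c1ccc(CSC(=S)N2CCN(c3ccncc3)CC2)cc1` differs from compound 1 by pyridin-4-yl in place of 4-methoxyphenyl on an amine nitrogen in a ring. Within the data shown here, none of the measured steps concerns this change: the only step, between compound 2 and compound 3, moves a methyl group on a piperidine ring and touches no aromatic group on the amine nitrogen. Among the measured compounds shown here, with no step bearing on it, the expected change from compound 1 to compound 4 in this assay is uncertain, and compound 4 is estimated at 40%, between 15% and 75%, an expected step of a number 17.1 percentage points higher from compound 1 to compound 4 (beyond the scatter).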

Compound 4, a percentage reported as inhibition, at one concentration (the size of the read-out at that concentration, not a potency): 87.1%
Beside the measured number, compound 4's estimate is 47.1 percentage points below it; measured number above the stated range.
By their numbers in this assay, from the lowest: compound 1; then compounds 3, 2 and 4 (each within the scatter of the next).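

Placing pyridin-4-yl instead of 4-methoxyphenyl on the amine nitrogen in a ring gives a number 64.2 percentage points higher from compound 1 to compound 4 (beyond the scatter) in this assay, so the read-out depends strongly on the aromatic group at this place. Among these compounds, the only earlier step (a number 5 percentage points lower from compound 2 to compound 3 (within the scatter)) moved a methyl group on a piperidine ring and could not show this. No available evidence explains the size of this step. The compounds shown leave open whether the step follows from gaining the ring nitrogen or from losing the methoxy group. They also leave open how an unsubstituted phenyl or a pyridin-3-yl group would read at this place.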